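The compounds below may be only part of what the source reports. "The series", "measured", "known", "first", "only" and "open" are said of these compounds alone.

Measured in a physicochemical assay for lipophilicity; a higher number here means a more lipophilic compound, a lower number a more polar compound:
compound 1 `CC1CCN(Cc2c(-c3nnc(SC(C)C)n3-c3ccccc3)n(C)c3ccccc23)CC1`: 5.96
compound 2 `CC(C)Sc1nnc(-c2c(CNCC3CC3)c3cc(F)ccc3n2C)n1-c1ccccc1`: 5.4
compound 3 `CC1CCN(Cc2c(-c3nnc(SC(C)C)n3-c3ccccc3)n(C)c3ccc(F)cc23)CC1`: 6.12

Compound 1 stands second highest of the three numbers in this assay. Its nearest neighbour is compound 3, reached by a number 0.16 log units higher from compound 1 to compound 3 (within the scatter), so the two cannot be told apart. Within the data shown here, its furthest neighbour is compound 2, whose value lies below that of compound 1 by more than the scatter; no single-point step joins these two compounds, so only the two values themselves speak here.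

Compound 4 `CC1CN(Cc2c(-c3nnc(SC(C)C)n3-c3ccccc3)n(C)c3ccccc23)CC(C)O1` differs from compound 1 in one place: 2,6-dimethylmorpholin-4-yl in place of 4-methylpiperidin-1-yl on a saturated chain carbon bound to an aromatic carbon. Of the measured steps, only a number 0.72 log units higher from compound 2 to compound 3 (beyond the scatter) touches the same place; it shows that swapping the group on the saturated chain carbon bound to an aromatic carbon can move this assay by a modest amount beyond the scatter. The step of a number 0.16 log units higher from compound 1 to compound 3 (within the scatter) lies elsewhere and does not bear on the question. Among the measured compounds shown here, no measured pair contains the 2,6-dimethylmorpholin-4-yl group, so the direction cannot be read from these three compounds alone. The working expectation is a modest fall, a number 0.41 log units lower from compound 1 to compound 4 (beyond the scatter), with the possibility that the change stays within the scatter. Compound 4 is therefore estimated at 5.55, expected between 5.1 and 6.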

Compound 4, partition coefficient: 5.13
Compound 4: middle estimate off by 0.42 log units, on the high side; measured number inside the range.
By their numbers in this assay, from the lowest: compounds 4 and 2 (each within the scatter of the next); then compounds 1 and 3 (each within the scatter of the next).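

In this assay, among these compounds, the step of a number 0.83 log units lower from compound 1 to compound 4 (beyond the scatter) is the first reading for the 2,6-dimethylmorpholin-4-yl group on a saturated chain carbon bound to an aromatic carbon, and it fixes the direction of this change as downward, beyond the scatter. Together with a number 0.72 log units higher from compound 2 to compound 3 (beyond the scatter), it gives two pairs that change only at this place, and in both the compound carrying 4-methylpiperidin-1-yl has the higher number, although the partner group differs and the two pairs rest on differently substituted cores. The change replaces a ring with one hetero atom by a ring with two and adds a heavy atom, but nothing measured here explains the step.

The compounds shown do not separate the contribution of the ring oxygen from that of the two methyl groups on the morpholine ring; an unsubstituted morpholin-4-yl group on the same carbon would help to divide the step. As far as these compounds go, the fluoro change has been read only with 4-methylpiperidin-1-yl, so its step with 2,6-dimethylmorpholin-4-yl remains open.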